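The source may hold more compounds than are shown below. What is called first, only, known or untested is meant among the compounds shown, and "the series" means these compounds.

Three compounds have been measured in a functional assay on K562 cells (Homo sapiens), read by MTT assay, with a stated time of 3 days (a higher number here means a weaker inhibitor, a lower number a stronger inhibitor), and a fourth awaits measurement:

Compound 1 `CNc1ncnc2[nH]cc(Sc3cccs3)c12`: 4950 nM
Compound 2 `c1csc(Sc2c[nH]c3ncnc(-c4cccs4)c23)c1`: 5140 nM
Compound 3 `c1coc(-c2ncnc3[nH]cc(Sc4cccs4)c23)c1`: 4260 nM
Compound 4 `COc1ncnc2[nH]cc(Sc3cccs3)c12`: not yet measured

Compound 3 gives 4260 nM, which lies within the scatter of the other two values. The change now followed is methoxy in place of furan-2-yl on an aromatic carbon. Going by the values given here, three measured steps bear on it, all of them exchanges on that aromatic carbon: a 1.0-fold higher number from compound 1 to compound 2 (0.02 log units; within the scatter), a 1.2-fold lower number from compound 1 to compound 3 (0.07 log units; within the scatter) and a 1.2-fold lower number from compound 2 to compound 3 (0.08 log units; within the scatter). Each lies within the scatter, so methylamino, thiophen-2-yl and furan-2-yl gave values that cannot be told apart in this assay. Among the compounds with values here, none of these steps involves methoxy, so the data hold no direct precedent for this group. No change beyond the scatter is expected, and the expected step is a 1.1-fold higher number from compound 3 to compound 4 (0.04 log units; within the scatter). For compound 4 the estimate is 4700 nM, with an expected range from 2700 nM to 8000 nM.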

Compound 4, half-maximal inhibitory concentration: > 50000 nM
Compound 4: no number, only a limit; the forecaster's own chance of this, stated with the estimate: 5%; middle value at least 10-fold (1.02 log units) away from the limit.
By their numbers in this assay, from the lowest: compounds 3, 1 and 2 (each within the scatter of the next). At a limit, above all of these: compound 4.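

In this assay compound 4 has no number, only a limit: the limit of > 50000 nM in this assay, at which 1 of the 4 values shown sits.

This position, where methylamino, thiophen-2-yl and furan-2-yl could not be told apart, does respond to the group it carries: the new steps are an at least 11-fold higher number from compound 3 to compound 4 (1.06 log units; beyond the scatter), an at least 10-fold higher number from compound 1 to compound 4 (1.00 log units; beyond the scatter) and an at least 9.7-fold higher number from compound 2 to compound 4 (0.98 log units; beyond the scatter), all beyond the scatter. Compound 1 also carries a group with no ring, yet it stays in the range of compound 2 and compound 3, so the absence of a ring alone does not separate methoxy from the other groups.

The limit leaves the full size of these steps unknown. Going by these compounds, whether the loss is tied to methoxy alone stays open, and an ethoxy group, a hydroxyl group or a primary amine on this carbon would bear on that.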